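This account rests on a few compounds, and the source may have more. Where it says the series, first, only, none or still open, it means among the compounds named here.

In a functional assay on HCT-116 cells (Homo sapiens) for cytotoxicity, with a stated time of 3 days (a lower number here means a stronger inhibitor, a higher number a weaker inhibitor), compound 1 (`Ic1nc2ccccc2o1`) gives > 40000 nM, which is a limit and not a measured number. Compound 2 (`C=Cc1nc2ccccc2o1`) gives > 40000 nM, and this too is a limit. Compound 2 therefore has no exact place on the scale. Within the data shown here, the one measured step is a step that the two limits leave unreadable from compound 1 to compound 2, where vinyl replaces iodo, so it offers no size to carry forward.

Compound 3 (`C#Cc1nc2ccccc2o1`) differs from compound 2 in a single group: ethynyl in place of vinyl on an aromatic carbon. Put simply, ethynyl stands in place of vinyl on an aromatic carbon, and a triple bond outside the aromatic rings replaces a double bond. Among the measured compounds shown here, the only evidence that bears on this change is the limit of > 40000 nM in this assay, at which 2 of the 2 values shown sit. Neither measured compound provides a number, so nothing supports a step of any particular size or direction, and no change beyond the usual scatter is expected. The estimated step is a number no higher from compound 2 to compound 3 (the limit leaves the size open), and this expectation is a weak one. Compound 3 is expected near 40000 nM, with an estimated range from 10000 nM to 80000 nM, and it may well return only a limit.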

Compound 3, half-maximal inhibitory concentration: 11600 nM
Compound 3: the middle estimate sits 3.4-fold (0.54 log units) above what was measured; the range from low to high includes it.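

Among these compounds, with ethynyl at this place, on the aromatic carbon next to the ring nitrogen and next to the ring oxygen, this assay gives a measured number for the first time, and the change from vinyl brings an at least 3.4-fold lower number from compound 2 to compound 3 (0.53 log units; beyond the scatter). Set against iodo, the same position shows an at least 3.4-fold lower number from compound 1 to compound 3 (0.53 log units; beyond the scatter), so this single group on the shared core is enough to lift the series off its limit. Vinyl and ethynyl each hold 2 heavy atoms, so the visible difference is a triple bond outside the aromatic rings in place of a double bond, but the data give no cause for the step and offer only this: the limit of > 40000 nM in this assay, at which 2 of the 3 values shown sit.

From the compounds shown here alone, the true size of both steps stays open, since only compound 3 has an exact value and the compounds it is compared with sit at limits. Also open, going by these compounds, is whether the gain depends on the triple bond itself, which a nitrile at this place could test, or whether it would survive a longer chain on the far end of the ethynyl group.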